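Compound 3 to compound 4: one further methoxy

The compounds below may be only part of what the source reports. "The series", "measured", "known", "first", "only" and "open" are said of these compounds alone.

Measured in an ADME assay on BJ cells (Homo sapiens) for cytotoxicity, read by MTT assay, with a stated time of 72 h; a higher number here means a weaker inhibitor, a lower number a stronger inhibitor:
- compound 1 `COc1cc(CNc2ncnc3c2ncn3C2CCCCO2)cc(OC)c1OC`: > 100000 nM, a limit
- compound 2 `COc1ccc(CNc2ncnc3c2ncn3C2CCCO2)cc1`: > 100000 nM, a limit
- compound 3 `COc1ccc(CNc2ncnc3c2ncn3C2CCCO2)cc1OC`: > 100000 nM, a limit

Compound 3 gives > 100000 nM, which is a limit and not a number. Within the data shown here, no measured compound in this set has a readable number, as the series stands at the limit of > 100000 nM in this assay, at which 3 of the 3 values shown sit.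

The next compound is compound 4 `COc1cc(CNc2ncnc3c2ncn3C2CCCO2)cc(OC)c1OC`, and the change is methoxy in place of hydrogen on an aromatic carbon. This is methoxy in place of hydrogen on an aromatic carbon, ortho to a methoxy group and meta to another.

Among the measured compounds shown here, the only measured step of the same kind is a step that the two limits leave unreadable from compound 2 to compound 3, so it gives no size to carry over. It does show that the same kind of change left the value at the limit. No step beyond the scatter is expected in this assay, and the estimated step is a number no higher from compound 3 to compound 4 (the limit leaves the size open). For compound 4 the expected value is 100000 nM, with an estimated range of 50000 nM to 200000 nM. A further limit is the most likely report.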

Compound 4, half-maximal inhibitory concentration: > 100000 nM
Compound 4: no number, only a limit; the forecaster's own chance of this, stated with the estimate: 90%; the middle value lies on the limit itself.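

In this assay compound 4 gives > 100000 nM, a limit and not a number. Among these compounds, no step to compound 4 from compound 3 or from compound 1 can be read. The compounds shown leave open whether any change on the shared core would give a readable number in this assay.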